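Heteroaryl swap on the sulfur of compound 2

The source may report more compounds than this note shows. Statements on the series, on what has been measured and on what is new or still open speak of the compounds shown alone.

Going by the values given here, compound 2 `Cc1nnc(SCC(=O)Nc2ccc(-c3nc(-c4ccccc4)c(-c4ccccc4)n3C)cc2)s1` gives 90.5% in a functional assay on HT-29 cells (Homo sapiens) for cytotoxicity, read by MTT assay, with a stated time of 24 h, tested at 80 ug/mL (a higher number here means a stronger effect of the compound at the concentration tested, a lower number a weaker effect), the highest of the two numbers so far; compound 1 `Cn1c(-c2ccc(NC(=O)CCl)cc2)nc(-c2ccccc2)c1-c1ccccc1` gives 76.1%. Among the compounds with values here, the one measured step, a number 14.4 percentage points higher from compound 1 to compound 2 (beyond the scatter), replaces a chloro with the whole (5-methyl-1,3,4-thiadiazol-2-yl)sulfanyl group and so only partly bears on exchanging one heteroaryl for another on the sulfur. Compound 3 `Cn1ccnc1SCC(=O)Nc1ccc(-c2nc(-c3ccccc3)c(-c3ccccc3)n2C)cc1` differs from compound 2 by 1-methyl-1H-imidazol-2-yl in place of 5-methyl-1,3,4-thiadiazol-2-yl on a sulfur. Within the data shown here, with no measured step for such a swap, no movement beyond the scatter is expected. Compound 3 is expected to give 85% in this assay, within 70% to 95%. The expected step is a number 5.5 percentage points lower from compound 2 to compound 3 (within the scatter).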

Compound 3, a percentage reported as activity, at one concentration (the size of the read-out at that concentration, not a potency): 69.4%
The estimate for compound 3 lay 15.6 percentage points above the measured number, outside the stated range (below it).
By their numbers in this assay, from the lowest: compounds 3 and 1 (each within the scatter of the next); then compound 2.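

In this assay the heteroaryl on the sulfur is not interchangeable: 1-methyl-1H-imidazol-2-yl in place of 5-methyl-1,3,4-thiadiazol-2-yl gives a number 21.1 percentage points lower from compound 2 to compound 3 (beyond the scatter) and removes the gain that compound 2 showed over the chloro compound. With (1-methyl-1H-imidazol-2-yl)sulfanyl in place of chloro, the series shows a number 6.7 percentage points lower from compound 1 to compound 3 (within the scatter), so this exchange gives no readable change. Nothing measured accounts for the difference between the two heteroaryl groups.

Still open, on these data alone, is whether a morpholine in place of the heteroaryl sulfanyl group, or a longer chain in place of the saturated chain carbon, would keep the number of compound 2.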